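Chlorodimethylaminobenzyl in Place of Ethoxybenzyl: Expected Tolerance

A few compounds are considered here, and "the series" means these few. Any claim that something is new, unique, unknown or untested is made for them only; others in the source may bear on it.

Three compounds of one series have been examined in a toxicity assay on MDCK cells (Canis lupus familiaris) for cytotoxicity, read by crystal violet staining, with a stated time of 48 h; a lower number here means that less compound is tolerated, a higher number that more compound is tolerated. Compound 1 `CCc1ccc2[nH]c(=O)c(CN(Cc3ccc(F)cc3)Cc3ccc(C(C)(C)C)cc3)cc2c1` gives > 33000 nM in this assay, which is a limit of the assay rather than a number. Compound 2 `CCc1ccc2[nH]c(=O)c(CN(Cc3ccc(F)cc3)Cc3ccc(-c4ccccc4)cc3)cc2c1` gives > 5000 nM in this assay, again a limit. The step that the two limits leave unreadable from compound 1 to compound 2 therefore cannot be read. Compound 3 `CCOc1ccc(CN(Cc2ccc(C(C)(C)C)cc2)Cc2cc3cc(C)ccc3[nH]c2=O)cc1` stands at > 10000 nM in this assay, once more a limit. Among the measured compounds shown here, all three measured values thus sit at limits, as the lines (the limit of > 10000 nM in this assay, at which 1 of the 3 values shown sits), the limit of > 33000 nM in this assay, at which 1 of the 3 values shown sits, and the limit of > 5000 nM in this assay, at which 1 of the 3 values shown sits, record, and no measured step between them has a readable size.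

Compound 4 `Cc1ccc2[nH]c(=O)c(CN(Cc3ccc(C(C)(C)C)cc3)Cc3ccc(N(C)C)c(Cl)c3)cc2c1` differs from compound 3 in one place: 3-chloro-4-(dimethylamino)phenyl in place of 4-ethoxyphenyl on a saturated chain carbon bound to an amine nitrogen. No measured step touches this change, since the only pair that differs in one place, compound 1 and compound 2, is unreadable, and the benzyl substituents of the other pairs differ in more than one place. The expectation for compound 4 therefore rests on the fact that none of the three measured compounds reached a readable concentration. Compound 4 is expected to give about 20000 nM in this assay, within 5000 nM to 60000 nM, most probably again as a limit only. The step that the limit leaves unreadable from compound 3 to compound 4 that this estimate means is expected to stay within the scatter.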

Compound 4, half-maximal cytotoxic concentration: > 10000 nM
Compound 4: a limit, no number; the forecaster's own chance of this, stated with the estimate: 70%; the middle value is on the limit's open side.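

Compound 3 and compound 4 both stand at a limit of this assay and not at a number, so the step between them, 3-chloro-4-(dimethylamino)phenyl in place of 4-ethoxyphenyl, cannot be read: the limit of > 10000 nM in this assay, at which 2 of the 4 values shown sit.

The compounds shown leave open what the half-maximal cytotoxic concentration of any of the four actually is.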